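From hydroxy to amino in the nitro series

The source may hold more compounds than are shown below. What is called first, only, known or untested is meant among the compounds shown, and "the series" means these compounds.

Compound 1 `O=C(O)c1ccc(C(=O)/C(=C\c2ccc(Cl)c([N+](=O)[O-])c2)SCc2ccc(F)cc2)cc1` and compound 2 `O=C(O)c1ccc(C(=O)/C(=C\c2ccc(O)c([N+](=O)[O-])c2)SCc2ccc(F)cc2)cc1` differ in a single group on the shared core. In a functional assay on DU-145 cells (Homo sapiens) for inhibition, read by trypan blue exclusion, with a stated time of 96 h (a higher number here means a weaker inhibitor of growth, a lower number a stronger inhibitor of growth), compound 1 gives 1000 nM. Compound 2 gives > 100000 nM, which is a limit of the assay and not a number. Compound 3 `Nc1ccc(/C=C(/SCc2ccc(F)cc2)C(=O)c2ccc(C(=O)O)cc2)cc1[N+](=O)[O-]` follows from compound 2 with amino in place of hydroxy on an aromatic carbon, so amino replaces hydroxy ortho to a nitro group. Among the compounds with values here, the only measured step bearing on this is an at least 100-fold higher number from compound 1 to compound 2 (2.00 log units; beyond the scatter), a large one beyond the scatter, at the same place on the ring. Within the data shown here, it shows that this place matters, but it holds no amino example. Compound 3 is therefore expected to stay on the weak side in this assay, moving to a lower number if it moves measurably. The estimated step is an at least 3.3-fold lower number from compound 2 to compound 3 (0.52 log units; beyond the scatter). For compound 3 the expected value is 30000 nM, with an estimated range of 5000 nM to 100000 nM.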

Compound 3, concentration for 50% growth inhibition: 10000 nM
The estimate for compound 3 lay 3.0-fold (0.48 log units) above the measured number; measured number inside the range.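

In this assay, amino in place of hydroxy gives an at least 10-fold lower number from compound 2 to compound 3 (1.00 log units; beyond the scatter), so the loss seen with hydroxy does not extend to every group at this place. From the compounds shown here alone, the true size of that step stays unknown, because compound 2 stands at a limit of the assay and not at a number: the limit of > 100000 nM in this assay, at which 1 of the 3 values shown sits. Amino still falls short of chloro, with a 10-fold higher number from compound 1 to compound 3 (1.00 log units; beyond the scatter), and since hydroxy and amino have the same printed counts of hydrogen-bond donors and acceptors, those counts alone do not separate them.

Open, going by these compounds, is where a methoxy, a methylamino or a bromo group at this place would fall relative to chloro, amino and hydroxy. Also open, on these data alone, is whether that order of the three holds when a nitrile replaces the nitro group.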